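Dichloro to Dimethoxy at the Carbonyl Aryl Group

A few compounds are considered here, and "the series" means these few. Any claim that something is new, unique, unknown or untested is made for them only; others in the source may bear on it.

compound 1, `COc1ccc(-c2cc(/C=C/C(=O)c3ccc(OC)c(OC)c3)[nH]n2)cc1`: 91%
compound 2, `COc1cc(-c2cc(/C=C/C(=O)c3ccc(Cl)c(Cl)c3)[nH]n2)cc(OC)c1OC`: 102%
compound 3, `COc1ccc(-c2cc(/C=C/C(=O)c3cc(OC)c(OC)c(OC)c3)[nH]n2)cc1OC`: 93%

These three compounds were tested in a functional assay on MDA-MB-231 cells (Homo sapiens) for cytotoxicity, read by sulforhodamine B assay, with a stated time of 48 h, tested at 0.1 uM; on this read-out higher numbers stand for a weaker effect at the one concentration tested and lower numbers for a stronger effect. Compound 2 gives the highest of the three numbers; compound 3 sits nearest to it, within the scatter, while compound 1 lies beyond the scatter. Compound 4, `COc1ccc(C(=O)/C=C/c2cc(-c3cc(OC)c(OC)c(OC)c3)n[nH]2)cc1OC`, has not yet been measured. It differs from compound 2 in one place: 3,4-dimethoxyphenyl in place of 3,4-dichlorophenyl on a carbonyl carbon. For the measured compounds named here, no step between two measured compounds covers this change, so the methoxy-bearing compounds 1 and 3 are the only guide, and both sit close to compound 2. Compound 4 is therefore expected to show no shift beyond the scatter, leaning slightly lower, a number 9 percentage points lower from compound 2 to compound 4 (within the scatter). The estimate for compound 4 is 93%, within 80% to 105%.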

Compound 4, a percentage reported as activity, at one concentration (the size of the read-out at that concentration, not a potency): 101%
The estimate for compound 4 lay 8 percentage points below the measured number; measured number inside the range.
By their numbers in this assay, from the lowest: compounds 1, 3, 4 and 2 (each within the scatter of the next, the first and the last beyond it).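

In this assay, the step at this position, on a carbonyl carbon, gives a number 1 percentage points lower from compound 2 to compound 4 (within the scatter) when 3,4-dimethoxyphenyl stands in place of 3,4-dichlorophenyl. With the rest of the molecule held the same, this single concentration therefore does not tell the two groups apart. Nothing available bears on why the two groups read alike.

Going by these compounds, it remains open whether an amine or a carboxylic acid on the aryl group at this carbonyl carbon would move the read-out beyond the scatter. On these data alone, it also remains open whether the two groups would separate at other concentrations.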